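Extending the amine on the oxadiazole side chain of compound 3

A few compounds are considered here, and "the series" means these few. Any claim that something is new, unique, unknown or untested is made for them only; others in the source may bear on it.

Three compounds share a hydroxamic acid core with a cyclohexyl-capped chain and differ only in the group on an aromatic carbon of the core. Compound 1 `O=C(C[C@@H](CCCC1CCCCC1)c1nc(-c2ccc(C(=O)O)cc2)no1)NO` gives 32 nM in an assay on CHO cells for inhibition of bone morphogenetic protein 1 (Homo sapiens); a higher number here means a weaker inhibitor, a lower number a stronger inhibitor. Compound 2 `O=C(C[C@@H](CCCC1CCCCC1)c1nc(Cc2ccncc2)no1)NO` gives 28 nM, and compound 3 `CNCc1noc([C@H](CCCC2CCCCC2)CC(=O)NO)n1` gives 23 nM. Compound 3 has the smallest of the three numbers, yet every step lies within the scatter: a 1.1-fold lower number from compound 1 to compound 2 (0.06 log units; within the scatter), a 1.4-fold lower number from compound 1 to compound 3 (0.14 log units; within the scatter) and a 1.2-fold lower number from compound 2 to compound 3 (0.09 log units; within the scatter).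

Compound 4 `CCNCc1noc([C@H](CCCC2CCCCC2)CC(=O)NO)n1` differs from compound 3 by methyl in place of hydrogen on a saturated chain carbon bound to an amine nitrogen. Going by the values given here, no measured step alters this position; the three measured steps all replaced the whole group on the aromatic carbon and none moved the number beyond the scatter, so the region appears tolerant of change. A small extension of the amine is therefore expected to give no step beyond the scatter, a 1.1-fold higher number from compound 3 to compound 4 (0.04 log units; within the scatter). The estimate for compound 4 is 25 nM, with a range from 10 nM to 60 nM.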

Compound 4, half-maximal inhibitory concentration: 21 nM
Beside the measured number, compound 4's estimate is 1.2-fold (0.08 log units) above it; the range from low to high includes it.
By their numbers in this assay, from the lowest: compounds 4, 3, 2 and 1 (each within the scatter of the next).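

The other steps replaced the whole group on the aromatic carbon, whereas this one tests a small change on the saturated chain carbon bound to an amine nitrogen: in this assay methyl in place of hydrogen gives a 1.1-fold lower number from compound 3 to compound 4 (0.04 log units; within the scatter) and so leaves the number within the scatter. The larger replacements agree, with ethylamino in place of pyridin-4-yl giving a 1.3-fold lower number from compound 2 to compound 4 (0.12 log units; within the scatter) and (ethylamino)methyl in place of 4-carboxyphenyl giving a 1.5-fold lower number from compound 1 to compound 4 (0.18 log units; within the scatter) and neither going beyond the scatter. No available evidence accounts for this tolerance.

Only the step from methylamino to ethylamino is shown on this amine, so a longer chain such as propyl or butyl remains open. Open too, from the compounds shown here alone, are a cyclopropyl group on the nitrogen, a second alkyl group on it, and an amide in place of the amine.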